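Swapping the Amide Link of a Selenocyanate Side Chain

The compounds below may be only part of what the source reports. "The series", "measured", "known", "first", "only" and "open" are said of these compounds alone.

Measured compounds:
- compound 1, `COc1ccc(N(C)c2nc(C)nc3ccccc23)cc1C(=O)NCC[Se]C#N`: 1170 nM
- compound 2, `C[Se]c1ccc(N(C)c2nc(C)nc3ccccc23)cc1C`: 8 nM
- compound 3, `Cc1nc(N(C)c2ccc([Se]C#N)c(F)c2)c2ccccc2n1`: 8 nM

All three compounds share a core and were tested in a functional assay on RKO cells (Homo sapiens) for inhibition, read by MTT assay, with a stated time of 48 h; on this read-out higher numbers stand for weaker inhibition and lower numbers for stronger inhibition. Compound 1 gives the highest number of the three, and both compound 2 and compound 3 give numbers far lower, well beyond the usual scatter, so compound 1 is the weakest inhibitor among the measured compounds.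

Compound 4, `COc1ccc(N(C)c2nc(C)nc3ccccc23)cc1C(=O)OCC[Se]C#N`, has not yet been measured. It differs from compound 1 in one place: a group of 6 heavy atoms (3 carbon, 1 nitrogen, 1 oxygen, 1 selenium; no ring) in place of a group of 6 heavy atoms (3 carbon, 2 nitrogen, 1 selenium; no ring), on a carbonyl carbon. Compound 1 thus has an amide linking its side chain to the core, and in compound 4 that amide becomes an ester, so the group that enters has 0 hydrogen-bond donors and 2 hydrogen-bond acceptors where the group that leaves has 1 hydrogen-bond donor and 1 hydrogen-bond acceptor.

Among the measured compounds shown here, no measured pair shows this change, so the step is expected to be small, near the scatter, most likely toward a slightly higher number a 1.3-fold higher number from compound 1 to compound 4 (0.11 log units; within the scatter). Compound 4 is therefore expected to give about 1500 nM in this assay, with a range from 400 nM to 6000 nM.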

Compound 4, half-maximal inhibitory concentration: 2390 nM
For compound 4 the middle estimate is 1.6-fold (0.20 log units) below the measured one; the range from low to high includes it.
By their numbers in this assay, from the lowest: compounds 2 and 3 (each within the scatter of the next); then compound 1; then compound 4.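

In this assay, changing the amide link to an ester on the carbonyl carbon gives a 2.0-fold higher number from compound 1 to compound 4 (0.31 log units; beyond the scatter), a modest step that lies just beyond the usual scatter. Among the compounds shown here, this is the first pair that differs in one place, so it isolates the link, which the earlier compounds could not do: removing the amide hydrogen, and with it the group's 1 hydrogen-bond donor, shifts the number only modestly and in the direction of weaker inhibition. Nothing available here accounts for the ester's higher number.

The compounds shown leave open how a carboxylic acid or a ketone at this carbonyl carbon would read. They also leave open whether an amide or an ester carrying a longer chain before the selenocyanate would show the same small difference.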